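Cytotoxicity of Two Measured Variants and One Untested Variant

The source may report more compounds than this note shows. Statements on the series, on what has been measured and on what is new or still open speak of the compounds shown alone.

Measured so far:
Compound 1, `Cc1cn(C2CC(N=[N+]=[N-])C(COC(=O)OCCCCCCCCO)O2)c(=O)[nH]c1=O` — > 50000 nM (a limit of the assay, not a number)
Compound 2, `Cc1cn(C2CC(N=[N+]=[N-])C(COC(=O)OCCCCCCO)O2)c(=O)[nH]c1=O` — > 50000 nM (a limit of the assay, not a number)

In a functional assay on MT4 cells (Homo sapiens) for cytotoxicity (on this read-out lower numbers stand for higher toxicity in this test and higher numbers for lower toxicity in this test), compound 1 gives > 50000 nM, which is a limit and not a measured number. Compound 2 likewise gives > 50000 nM, again a limit. Because both values are limits, the step that the two limits leave unreadable from compound 1 to compound 2 cannot be read. Compound 2 therefore stands at the limit, as the limit of > 50000 nM in this assay, at which 2 of the 2 values shown sit, states.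

Compound 3, `Cc1cn(C2CC(N=[N+]=[N-])C(COC(=O)CCCC(=O)O)O2)c(=O)[nH]c1=O`, differs from compound 2 in one place: 3-carboxypropyl in place of (6-hydroxyhexyl)oxy on a carbonyl carbon. Within the data shown here, the only measured step between neighbouring compounds is unreadable, so no measured step gives a direction for this change. The expected step of a number no higher from compound 2 to compound 3 (the limit leaves the size open) is therefore estimated as none beyond the scatter. Compound 3 is accordingly expected to give about 50000 nM in this assay, with a range from 15000 nM to 200000 nM, and most likely again only a limit rather than a number.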

Compound 3, half-maximal cytotoxic concentration: > 50000 nM
Compound 3: a limit, no number (the forecaster's own chance of this, stated with the estimate: 80%); the middle value sits exactly at the limit.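

In this assay, among these compounds, compound 3 gives > 50000 nM, which is a limit and not a number, and no step among compound 1, compound 2 and compound 3 can be read. Whether any of these changes alters toxicity in this assay stays open, with all three compounds sitting at one value: the limit of > 50000 nM in this assay, at which 3 of the 3 values shown sit.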